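Swapping the Amino Group of Compound 3 for a Chain

This account rests on a few compounds, and the source may have more. Where it says the series, first, only, none or still open, it means among the compounds named here.

Compound 1 `CCSc1nc(N)c2nc(O)n(Cc3ccccc3)c2n1` gives 0.1 uM in a functional assay (spleen, spleen) for activation, with Mus musculus as the target; on this read-out higher numbers stand for an effect only at larger amounts of compound and lower numbers for an effect already at smaller amounts.
Compound 2 `CCOc1nc(N)c2nc(O)n(Cc3ccccc3)c2n1` gives 0.1 uM in this assay.
Compound 3 `Nc1nc(N)c2nc(O)n(Cc3ccccc3)c2n1` gives 10 uM in this assay.

On these three numbers compound 3 stands highest, with compound 1 and compound 2 both well below it. Compound 4 `CCCC[S+]([O-])c1nc(N)c2nc(O)n(Cc3ccccc3)c2n1` differs from compound 3 by a group of 6 heavy atoms (4 carbon, 1 oxygen, 1 sulfur; no ring) in place of one nitrogen atom, on an aromatic carbon. Among the measured compounds shown here, the steps that bear on this are a 100-fold higher number from compound 1 to compound 3 (2.00 log units; beyond the scatter) and a 100-fold higher number from compound 2 to compound 3 (2.00 log units; beyond the scatter): each put amino in place of a chain on that carbon and raised the number greatly. The change to compound 4 runs the other way, setting a chain of a different kind in place of amino, so a large fall in the number is expected in this assay, about a 33-fold lower number from compound 3 to compound 4 (1.52 log units; beyond the scatter). Compound 4 is therefore estimated at 0.3 uM, within a range from 0.03 uM to 3 uM.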

Compound 4, minimum effective concentration: 0.01 uM
For compound 4 the middle estimate is 30-fold (1.48 log units) above the measured one, outside the stated range (below it).
By their numbers in this assay, from the lowest: compound 4; then compounds 1 and 2 (each within the scatter of the next); then compound 3.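

In this assay the group of 6 heavy atoms on this aromatic carbon does more than replace amino, with a 1000-fold lower number from compound 3 to compound 4 (3.00 log units; beyond the scatter). It also goes past both earlier chains, with a 10-fold lower number from compound 2 to compound 4 (1.00 log units; beyond the scatter) and a 10-fold lower number from compound 1 to compound 4 (1.00 log units; beyond the scatter), so this position accepts a larger group than ethoxy or ethylsulfanyl and the number still falls. Nothing measured here explains this.

The compounds shown leave open whether the longer chain or the oxygen on sulfur accounts for the fall. Butylsulfanyl or butoxy at this carbon would separate the two.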